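Swapping pentyloxy for methylsulfanyl on the shared core

The source may report more compounds than this note shows. Statements on the series, on what has been measured and on what is new or still open speak of the compounds shown alone.

In a functional assay on the whole organism (strain Sprague-Dawley) for inhibition, with Rattus norvegicus as the target, with a stated time of 10 min (a lower number here means that less compound is needed, a higher number that more compound is needed for the effect), compound 1 `CCCCOc1ccccc1-c1ncc(C(=O)O)c(=O)[nH]1` gives 0.5 mg/kg. Compound 2 `CCCCCOc1ccccc1-c1ncc(C(=O)O)c(=O)[nH]1` gives 3 mg/kg, the higher of the two numbers, so more of it is needed for the same effect. Compound 3 `CSc1ccccc1-c1ncc(C(=O)O)c(=O)[nH]1` keeps the shared core but changes the side chain: methylsulfanyl in place of pentyloxy on an aromatic carbon. In words, methylsulfanyl replaces pentyloxy on an aromatic carbon, ortho to a large group.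

Going by the values given here, only one measured step bears on this change: a 6.0-fold higher number from compound 1 to compound 2 (0.78 log units; beyond the scatter), where a methyl takes the place of a hydrogen on the chain. That step is beyond the scatter and shows that lengthening the chain raised the number in this one pair. Compound 3 moves the other way in chain size, which points to a lower number. However, no measured compound tests sulfur in place of oxygen, so this guide is weak. The expected change is small, a 2.0-fold lower number from compound 2 to compound 3 (0.30 log units; within the scatter), and it may not exceed the scatter. For compound 3, the estimated value in this assay is 1.5 mg/kg, with an expected range from 0.3 mg/kg to 8 mg/kg.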

Compound 3, dose for 50% inhibition: > 20 mg/kg
Compound 3: a limit, no number; the forecaster's own chance of this, stated with the estimate: 5%; middle value at least 13-fold (1.12 log units) away from the limit.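

In this assay compound 3 gives > 20 mg/kg, which is a limit of the assay and not a number. The earlier pair showed only that pentyloxy gives a higher number than butoxy, and a much smaller group on this aromatic carbon, ortho to a large group, does not bring the number back down: the change to methylsulfanyl gives an at least 6.6-fold higher number from compound 2 to compound 3 (0.82 log units; beyond the scatter), and measured against butoxy it gives an at least 40-fold higher number from compound 1 to compound 3 (1.60 log units; beyond the scatter), so among these three compounds a shorter side chain does not simply mean a lower number, and butoxy gives the lowest number of the three. The true size of both new steps stays unknown, since each of them rests on a single limit rather than on a measured number: the limit of > 20 mg/kg in this assay, at which 1 of the 3 values shown sits.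

Compound 3 changes the length of the side chain and puts sulfur in place of oxygen in one move, so the compounds shown cannot say which of the two matters more. A methoxy group would test the short chain with oxygen kept, and a butylsulfanyl group would test sulfur with the chain length of compound 1 kept.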